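The source may hold more compounds than are shown below. What is called first, only, known or untested is meant among the compounds shown, and "the series" means these compounds.

Values so far in a functional assay on the whole organism for inhibition, with Cavia porcellus as the target; on this read-out higher numbers stand for an effect only at larger amounts of compound and lower numbers for an effect already at smaller amounts:
- compound 1 `COc1ccccc1OCC1SCCN1C(=O)CN` gives 57 mg/kg
- compound 2 `COc1ccccc1OCC1SCCN1C(=O)CNC(C)=O` gives 40 mg/kg
- compound 3 `COc1ccccc1OCC1SCCN1C(C)=O` gives 46 mg/kg

Compound 3 at 46 mg/kg does not separate from the other two values. The measured 1.2-fold higher number from compound 2 to compound 3 (0.06 log units; within the scatter) and the measured 1.2-fold lower number from compound 1 to compound 3 (0.09 log units; within the scatter) set it level with both within the scatter, so the three compounds have no meaningful order yet.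

Compound 4 `C=CC(=O)N1CCSC1COc1ccccc1OC` keeps the shared core and alters only the group on the carbonyl carbon: vinyl in place of methyl on a carbonyl carbon. In words, this is vinyl in place of methyl on a carbonyl carbon.

Going by the values given here, no measured step makes this exact exchange. The closest evidence is the set of steps that alter the group on that same carbonyl carbon. Besides the two above, these include a 1.4-fold lower number from compound 1 to compound 2 (0.15 log units; within the scatter). All three stay within the scatter in this assay, and none of the three compounds goes against this flat picture. Three compounds are thin support, however, and none carries a vinyl group, so the range is kept wide.

The expected result is a 1.0-fold lower number from compound 3 to compound 4 (0.01 log units; within the scatter), with no step beyond the scatter and no preferred direction. For compound 4 the estimated value is 45 mg/kg, with an expected range from 22 mg/kg to 90 mg/kg.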

Compound 4, dose for half-maximal effect: 74 mg/kg
Compound 4: middle estimate off by 1.6-fold (0.22 log units), on the low side, within the range that was stated.
By their numbers in this assay, from the lowest: compounds 2, 3, 1 and 4 (each within the scatter of the next).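

In this assay, going by these compounds alone, vinyl in place of methyl on a carbonyl carbon whose other neighbour is an amide-type nitrogen in a ring gives a 1.6-fold higher number from compound 3 to compound 4 (0.21 log units; within the scatter), so the first group here with a double bond outside aromatic rings does not separate from methyl. The comparisons with the two remaining compounds, a 1.9-fold higher number from compound 2 to compound 4 (0.27 log units; within the scatter) and a 1.3-fold higher number from compound 1 to compound 4 (0.11 log units; within the scatter), stay within the scatter as well, although the step from compound 2 is the largest seen so far in the series. The flat picture at this position therefore now spans methyl, vinyl, aminomethyl and acetamidomethyl, with none of the four compounds going against it, and no supporting data bear on this result.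

Still open, as far as these compounds go, is whether any group on this carbonyl carbon gives a step beyond the scatter, for example a longer chain, a carboxylic acid or a tertiary amine. From the compounds shown here alone, all four compounds also share the same core, so it remains unknown whether vinyl and methyl would stay level on a core carrying, say, a chlorine atom in place of the methoxy group.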